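Swapping the Aryl Group on the Aromatic Nitrogen at the Limit

A few compounds are considered here, and "the series" means these few. Any claim that something is new, unique, unknown or untested is made for them only; others in the source may bear on it.

Compound 1 `CCOc1ccccc1-n1nncc1CN1C(=O)C2(C(C#N)=C(N)Oc3c(N)cc4nc5ccccc5nc4c32)c2ccccc21`: in a functional assay on HCT-116 cells (Homo sapiens) for antiproliferative activity, read by MTT assay, with a stated time of 48 h (a higher number here means a weaker inhibitor, a lower number a stronger inhibitor), compound 1 gives > 50000 nM, which is a limit of the assay and not a number.
Compound 2 `N#CC1=C(N)Oc2c(N)cc3nc4ccccc4nc3c2C12C(=O)N(Cc1cnnn1-c1cc(Cl)ccc1Cl)c1ccccc12`: in this assay compound 2 gives > 50000 nM, again a limit of the assay.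

Both measured compounds share one core and differ only in the aryl group on an aromatic nitrogen. The step from compound 1 to compound 2 is a step that the two limits leave unreadable from compound 1 to compound 2, with 2,5-dichlorophenyl in place of 2-ethoxyphenyl; since both ends are limits, its size cannot be read. Among the compounds with values here, compound 2 thus stands only at a limit, and the one further value shown is a limit as well, as the limit of > 50000 nM in this assay, at which 2 of the 2 values shown sit, states.

Compound 3 `N#CC1=C(N)Oc2c(N)cc3nc4ccccc4nc3c2C12C(=O)N(Cc1cnnn1-c1ccc(Cl)cc1[N+](=O)[O-])c1ccccc12` differs from compound 2 by 4-chloro-2-nitrophenyl in place of 2,5-dichlorophenyl on an aromatic nitrogen. Within the data shown here, the only measured step does not give a readable size, so no direction beyond the scatter can be drawn from it; the single fact at hand is that every measured value sits at the limit.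

Compound 3 is therefore expected to give about 60000 nM, within a range from 15000 nM to 250000 nM. The expected step from compound 2 to compound 3 is a step that the limit leaves unreadable from compound 2 to compound 3, and the most likely outcome is once more a limit rather than a number.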

Compound 3, half-maximal inhibitory concentration: 28700 nM
Compound 3: the middle estimate sits 2.1-fold (0.32 log units) above what was measured; the range from low to high includes it.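

In this assay, within the data shown here, compound 3 gives 28700 nM, the first value at this position that is a number and not a limit, so the aryl group on the aromatic nitrogen can bring a compound of this series into the range the assay can read. Putting 4-chloro-2-nitrophenyl in place of the earlier groups gives an at least 1.7-fold lower number from compound 2 to compound 3 (0.24 log units; that floor lies within the scatter), and likewise an at least 1.7-fold lower number from compound 1 to compound 3 (0.24 log units; that floor lies within the scatter); both are only floors, so the true gaps may be larger, but what can be claimed so far does not pass the scatter. Compound 1 and compound 2 remain limits and not numbers, and the step between them still cannot be read: the limit of > 50000 nM in this assay, at which 2 of the 3 values shown sit.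

The compounds shown leave open whether the nitro group alone accounts for the readable number, as 4-chloro-2-nitrophenyl and 2,5-dichlorophenyl differ in more than one substituent. Also open, as far as these compounds go, is how an amine or a carboxylic acid on this phenyl ring would read in this assay, and whether any group here can move the value clearly beyond the scatter.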